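The compounds below may be only part of what the source reports. "The series", "measured", "known", "first", "only" and "open" are said of these compounds alone.

In an ADME assay on L132 cells (Homo sapiens) for cytotoxicity, read by MTT assay, with a stated time of 48 h (on this read-out higher numbers stand for weaker inhibition and lower numbers for stronger inhibition), compound 1 `C/C(=C\CC/C(C)=C/CC[C@@H]1[C@@]2(C)CCC(=O)C(C)(C)[C@H]2CC[C@@]1(C)O)CC/C=C(\C)C(=O)OCc1cn(-c2ccccc2[N+](=O)[O-])nn1` gives only a limit, > 150000 nM, and that is not a number. Where compound 1 stands is therefore known only as the limit of > 150000 nM in this assay, at which 1 of the 2 values shown sits. Compound 2 `C/C(=C\CC/C(C)=C/CC[C@@H]1[C@@]2(C)CCC(=O)C(C)(C)[C@H]2CC[C@@]1(C)O)CC/C=C(\C)C(=O)OCc1cn(C[C@@H]2O[C@H](n3ccc(=O)[nH]c3=O)C[C@H]2O)nn1` gives 148000 nM in this assay. Compound 3 `C/C(=C\CC/C(C)=C/CC[C@@H]1[C@@]2(C)CCC(=O)C(C)(C)[C@H]2CC[C@@]1(C)O)CC/C=C(\C)C(=O)OCc1cn(-c2ccc(Br)cc2)nn1` differs from compound 1 by 4-bromophenyl in place of 2-nitrophenyl on an aromatic nitrogen. No step between measured compounds is shown here, so the two values are all that guides the expectation, which is for no step beyond the scatter: the expected step is a number no higher from compound 1 to compound 3 (the limit leaves the size open). Compound 3 is thus estimated at 150000 nM in this assay, between 60000 nM and 300000 nM, with a real chance of a limit again.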

Compound 3, half-maximal inhibitory concentration: > 150000 nM
Compound 3: a limit, no number (the forecaster's own chance of this, stated with the estimate: 60%); the middle value sits exactly at the limit.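

Within the data shown here, compound 1 and compound 3 each give only a limit and not a number, and no step between them can be read: the limit of > 150000 nM in this assay, at which 2 of the 3 values shown sit. The compounds shown leave open whether 4-bromophenyl in place of 2-nitrophenyl changes the value at all in this assay.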